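The source may report more compounds than this note shows. Statements on the series, on what has been measured and on what is new or still open speak of the compounds shown alone.

Compound 3 `CCOc1ccc(Nc2nc3nonc3nc2Nc2ccccc2F)cc1` gives the highest number of the three measured in an assay on mitochondria from L6 cells (Rattus norvegicus) for activation, with a stated time of 90 min; on this read-out higher numbers stand for an effect only at larger amounts of compound and lower numbers for an effect already at smaller amounts: compound 3 gives 3800 nM, compound 1 `Fc1ccccc1Nc1nc2nonc2nc1Nc1ccccc1` gives 2200 nM and compound 2 `COc1ccc(Nc2nc3nonc3nc2Nc2ccccc2F)cc1` gives 1600 nM. Compound 4 `Fc1ccccc1Nc1nc2nonc2nc1Nc1ccc(C(F)(F)F)cc1` differs from compound 3 in one place: trifluoromethyl in place of ethoxy on an aromatic carbon. Going by the values given here, no measured step puts a trifluoromethyl in place of ethoxy, so the change has no direct precedent. The steps that touch the same aromatic carbon are all small: a 1.4-fold lower number from compound 1 to compound 2 (0.14 log units; within the scatter), a 1.7-fold higher number from compound 1 to compound 3 (0.24 log units; within the scatter) and a 2.4-fold higher number from compound 2 to compound 3 (0.38 log units; beyond the scatter). Since groups on that carbon have so far shifted the number only a little, the step to compound 4 is expected to stay close to the scatter, with no clear direction. Compound 4 is therefore estimated at 2500 nM, between 900 nM and 7000 nM, which means an expected step of a 1.5-fold lower number from compound 3 to compound 4 (0.18 log units; within the scatter).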

Compound 4, half-maximal effective concentration: 270 nM
Compound 4: middle estimate off by 9.3-fold (0.97 log units), on the high side; measured number below the stated range.
By their numbers in this assay, from the lowest: compound 4; then compounds 2, 1 and 3 (each within the scatter of the next, the first and the last beyond it).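

In this assay this aromatic carbon proves far more responsive than hydrogen, methoxy and ethoxy suggested: trifluoromethyl brings a 14-fold lower number from compound 3 to compound 4 (1.15 log units; beyond the scatter) and a 5.9-fold lower number from compound 2 to compound 4 (0.77 log units; beyond the scatter) and also an 8.1-fold lower number from compound 1 to compound 4 (0.91 log units; beyond the scatter). Compound 4 therefore stands clearly apart from all three earlier compounds, with the lowest number of the four. Nothing measured here explains this drop. On these data alone, whether it is particular to trifluoromethyl remains open, since a chlorine atom, a nitrile or an amine on the same carbon could give a similar or a different number. Whether the same change would act alike with another group in place of the fluorine on the other ring is also unknown.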